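A swapped group on an inactive compound

This account rests on a few compounds, and the source may have more. Where it says the series, first, only, none or still open, it means among the compounds named here.

In a functional assay on MCF7 cells (Homo sapiens) for antiproliferative activity, read by MTT assay (on this read-out lower numbers stand for stronger inhibition and higher numbers for weaker inhibition), compound 3 (`CC1(C)CCc2c(ccc(C(=O)/C=C/c3ccc(OCc4cn(-c5ccc(Cl)cc5)nn4)cc3)c2O)O1`) is reported as "not active" (no number reported) and so has no single number. In this assay compound 2 (`CCc1ccccc1-n1cc(COc2ccc(/C=C/C(=O)c3cc4c(cc3O)OC(C)(C)CC4)cc2)nn1`), whose core is arranged differently, is also reported as "not active" (no number reported) without a number. Among the measured compounds shown here, the only figure comes from compound 1 (`Cc1c(-n2cc(COc3ccc(/C=C/C(=O)c4cc5c(cc4O)OC(C)(C)CC5)cc3)nn2)cccc1[N+](=O)[O-]`), which gives 176000 nM and is a very weak inhibitor of these cells.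

Compound 4 (`CCc1ccccc1-n1cc(COc2ccc(/C=C/C(=O)c3ccc4c(c3O)CCC(C)(C)O4)cc2)nn1`) keeps the core of compound 3 and changes one group (2-ethylphenyl in place of 4-chlorophenyl on an aromatic nitrogen), with 2-ethylphenyl in place of 4-chlorophenyl on an aromatic nitrogen. For the measured compounds named here, no measured step shows what this swap does. Compound 2 carries the same 2-ethylphenyl group and gives "not active" (no number reported) in this assay, so that group offers no hint of a gain. I therefore expect at most a small step toward stronger inhibition, and a second report without a number is quite possible. If a number appears, the estimate for compound 4 is 200000 nM within a range of 80000 nM to 500000 nM for this very weak activity.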

Compound 4, half-maximal inhibitory concentration: "not active" (no number reported)
Nothing numeric was reported for compound 4, and the estimate cannot be compared.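

Compound 3 and compound 4 are both reported as "not active" without a number, so no step can be read from putting 2-ethylphenyl in place of 4-chlorophenyl, and nothing here offers an explanation. From the compounds shown here alone, whether this swap changes activity at all remains open.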